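This account rests on a few compounds, and the source may have more. Where it says the series, first, only, none or still open, it means among the compounds named here.

Within the data shown here, compound 1, `CC(=O)N[C@@H](C)C(=O)N(C)/N=N/c1ccc(Br)cc1`, stands at 2.8 in a physicochemical assay for lipophilicity, read by HPLC, in phosphate buffer, measured as octanol-water partition, at pH 7.4 (on this read-out lower numbers stand for lower lipophilicity and higher numbers for higher lipophilicity), the higher of the two numbers measured so far. Among the measured compounds shown here, the only other measured member of the series, compound 2, `CC(=O)NCC(=O)N(C)/N=N/c1ccc(C#N)cc1`, gives 1.1 in this assay, a number that lies below that of compound 1 by more than the usual scatter; compound 2 differs from compound 1 in more than one place, so no single step can be read from the pair.

Compound 3, `CC(=O)N[C@@H](C)C(=O)N(C)/N=N/c1ccc(C)cc1`, is not yet measured. It differs from compound 1 in one place only: methyl in place of bromo on an aromatic carbon.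

With no measured step of this kind in the series, the expectation rests on the structure alone. The step from compound 1 to compound 3 in this assay is expected to be small and downward, a number 0.30 log units lower from compound 1 to compound 3 (within the scatter), roughly at the edge of the scatter. Compound 3 is accordingly estimated at 2.5, with a range from 2.1 to 2.9.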

Compound 3, partition coefficient: 2.45
The estimate for compound 3 lay 0.05 log units above the measured number; measured number inside the range.
By their numbers in this assay, from the lowest: compound 2; then compound 3; then compound 1.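

In this assay the aromatic carbon para to a large group now has its first single-place reading: methyl in place of bromo gives a number 0.35 log units lower from compound 1 to compound 3 (beyond the scatter) with the rest of the structure unchanged. The earlier pair differed in more than one place and could not show this; here one heavy atom replaces one heavy atom, with no ring, hydrogen-bond donor, hydrogen-bond acceptor or net charge entering or leaving, and the number still moves. No measured information at hand explains the size of this step.

Open, as far as these compounds go, is how an amine, a carboxylic acid or a longer alkyl chain at this position would read in this assay against bromo and methyl. Also open, from the compounds shown here alone, is whether methyl in place of bromo gives a step of similar size and direction on any other core.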